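Cytotoxicity notes: compound 2 to compound 3

The compounds below may be only part of what the source reports. "The series", "measured", "known", "first", "only" and "open" are said of these compounds alone.

In an ADME assay on MT4 cells (Homo sapiens) for cytotoxicity (on this read-out lower numbers stand for higher toxicity in this test and higher numbers for lower toxicity in this test), compound 1 `O=c1[nH]c2ccc(Cl)cc2n1Cc1c(F)cccc1F` is reported only as a limit, > 424000 nM. Going by the values given here, compound 2 `Cc1ccc2[nH]c(=O)n(Cc3c(F)cccc3F)c2c1` gives 236000 nM, the only actual number so far.

The next structure, compound 3 `O=c1[nH]c2ccc(C(F)(F)F)cc2n1Cc1c(F)cccc1F`, differs from compound 2 by trifluoromethyl in place of methyl on an aromatic carbon. Among the compounds with values here, no measured step covers this exchange directly. As far as these compounds go, the nearest guide is an at least 1.7-fold lower number from compound 1 to compound 2 (0.25 log units; that floor lies within the scatter), with methyl in place of chloro, and it is open-ended, resting on (the limit of > 424000 nM in this assay, at which 1 of the 2 values shown sits). On that single step, only a small change is expected in this assay, leaning towards a higher number and probably not beyond the scatter. The expected step is a 1.3-fold higher number from compound 2 to compound 3 (0.10 log units; within the scatter). For compound 3 the estimated value is 300000 nM, with an expected range of 150000 nM to 600000 nM.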

Compound 3, half-maximal cytotoxic concentration: > 424000 nM
Compound 3 ended at the assay's limit; the forecaster's own chance of this, stated with the estimate: 50%; middle value at least 1.4-fold (0.15 log units) away from the limit.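

Trifluoromethyl on this aromatic carbon gives an at least 1.7-fold higher number from compound 2 to compound 3 (0.25 log units; that floor lies within the scatter) in this assay, so the exchange is known only as a floor, not as a measured size. Going by these compounds alone, compound 2, with methyl, remains the only compound with an actual number, while the chloro and trifluoromethyl compounds both stop at the limit, and the step between those two cannot be read. Read-outs at this position now consist mostly of limits, leaving little room to separate the groups: the limit of > 424000 nM in this assay, at which 2 of the 3 values shown sit.

As far as these compounds go, how far compound 1 and compound 3 actually lie from compound 2 stays open, so it is unknown whether either difference exceeds the scatter. Also open, from the compounds shown here alone, is how an amine or a carboxylic acid on this aromatic carbon would read in this assay.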